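The source may report more compounds than this note shows. Statements on the series, on what has been measured and on what is new or still open speak of the compounds shown alone.

Compound 1 `N#Cc1c(N)nc(SCC(=O)NCO)c(C#N)c1-c1ccc(OCC2CC2)cc1`: 8%
Compound 2 `C=C(C)COc1ccc(-c2c(C#N)c(N)nc(SCC(N)=O)c2C#N)cc1`: 4%
Compound 3 `CCOc1ccc(-c2c(C#N)c(N)nc(SCC(N)=O)c2C#N)cc1`: 20%

In an assay on CHO cells for displacement of a labelled ligand from adenosine receptor A3 (Homo sapiens), read by scintillation counting, with a stated time of 120 min, tested at 1 uM (a lower number here means less inhibition, a higher number more inhibition at the concentration tested (going by the name of the read-out)), compound 1 stands second highest of the three; compound 2 lies within the scatter of it, while compound 3 sits beyond the scatter above it. Within the data shown here, the only step measured so far, a number 16 percentage points higher from compound 2 to compound 3 (beyond the scatter), changes the group on the ether oxygen of the aryl ring, a different part of the shared core. Compound 4 `COC(=O)c1cccc(CSc2nc(N)c(C#N)c(-c3ccc(OCC4CC4)cc3)c2C#N)c1` carries the change (3-(methoxycarbonyl)phenyl in place of (hydroxymethyl)carbamoyl on a saturated chain carbon bound to a sulfur). Among the measured compounds shown here, no measured step touches this sulfur-bound chain, so nothing shows how this assay responds there; the expectation is a step of a number 2 percentage points higher from compound 1 to compound 4 (within the scatter), within the scatter. Compound 4 is therefore estimated at 10%, with a range of 0% to 30%.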

Compound 4, a percentage reported as inhibition, at one concentration (the size of the read-out at that concentration, not a potency): 4%
Compound 4: middle estimate off by 6 percentage points, on the high side; low and high end bracket the measured number.
By their numbers in this assay, from the lowest: compounds 2, 4 and 1 (each within the scatter of the next); then compound 3.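

In this assay, among these compounds, the swap of (hydroxymethyl)carbamoyl for 3-(methoxycarbonyl)phenyl on a saturated chain carbon bound to a sulfur gives a number 4 percentage points lower from compound 1 to compound 4 (within the scatter) and is the first measured change at this position. Going from 5 heavy atoms without a ring to 10 heavy atoms with an aromatic ring, and from 2 hydrogen-bond donors to 0, leaves the read-out within the scatter. No evidence is available to explain this result.

From the compounds shown here alone, whether a carboxylic acid or an amine in place of the methoxycarbonyl group would read differently stays open. So does whether a longer chain at this position would.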